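This account rests on a few compounds, and the source may have more. Where it says the series, first, only, none or still open, it means among the compounds named here.

Measured compounds:
- compound 1, `CC[C@H](C)C(=O)N1CCC(CC(=O)Nc2ccc(OC(F)(F)F)c(F)c2)CC1`: 7.68
- compound 2, `CCOC(=O)N1CCC(NC(=O)Nc2ccc(OC(F)(F)F)c(F)c2)CC1`: 5.94
- compound 3, `O=C(Nc1ccc(OC(F)(F)F)c(F)c1)NC1CCN(C(=O)C2CCCOC2)CC1`: 4.09

All three were read in a physicochemical assay for lipophilicity, read by HPLC, with a stated time of 90 min, tested at 100 uM; a lower number here means a more polar compound, a higher number a more lipophilic compound. Compound 1 gives 7.68 and stands highest of the three, with compound 2 nearest at 5.94 and compound 3 furthest at 4.09. Among the compounds with values here, the one directly comparable pair among them is compound 2 and compound 3, where the step was a number 1.85 log units lower from compound 2 to compound 3 (beyond the scatter), the change being oxan-3-yl in place of ethoxy on a carbonyl carbon.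

The unmeasured compound 4, `CC(C)C(=O)N1CCC(CC(=O)Nc2ccc(OC(F)(F)F)c(F)c2)CC1`, is reached from compound 1 by a single change: hydrogen in place of methyl on a saturated chain carbon, two bonds along the chain from a carbonyl carbon. Within the data shown here, no measured pair shows this kind of change; the step from compound 2 to compound 3 exchanges one group for another on a carbonyl carbon and does not speak to the loss of one carbon from a saturated chain. What remains is the count: compound 4 is compound 1 less a methyl. The expectation for compound 4 is therefore a small downward step in this assay, estimated at a number 0.38 log units lower from compound 1 to compound 4 (beyond the scatter), which is close to the scatter. Compound 4 is accordingly estimated at 7.3, with a range from 6.8 to 7.7.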

Compound 4, partition coefficient: 5.81
For compound 4 the middle estimate is 1.49 log units above the measured one, outside the stated range (below it).
By their numbers in this assay, from the lowest: compound 3; then compounds 4 and 2 (each within the scatter of the next); then compound 1.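

In this assay, the change from sec-butyl to isopropyl gave a number 1.87 log units lower from compound 1 to compound 4 (beyond the scatter) and this large step came from the loss of a single carbon, with no ring, no hydrogen-bond donor or acceptor and no net charge leaving. The earlier compounds shown here showed a large step only for the exchange of one group for another on a carbonyl carbon (a number 1.85 log units lower from compound 2 to compound 3 (beyond the scatter)) and said nothing about this position. The present pair shows that, on the core of compound 1, a methyl on a saturated chain carbon, two bonds along the chain from a carbonyl carbon, can by itself carry a large step in this read-out, though nothing measured here accounts for its size.

This single pair leaves open whether the loss of a methyl at this place would give a step of like size on any other core. It also leaves open how the number would respond if a longer chain such as n-pentyl, a cyclopropyl group, a hydroxyl or an amine stood at this place in the core of compound 1.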